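Moving the Methyl Around the Ring in Compound 4

The source may hold more compounds than are shown below. What is called first, only, known or untested is meant among the compounds shown, and "the series" means these compounds.

Of the compounds shown here, three have been measured in a functional assay on CHO cells for agonist activity at Free fatty acid receptor 1 (Homo sapiens), read by calcium flux; a lower number here means that less compound is needed, a higher number that more compound is needed for the effect. Compound 1 `Cc1cccc(C)c1-c1cccc(COc2ncc(CCC(=O)O)s2)c1` gives 65 nM. Compound 2 `CCOC(CC(=O)O)c1ccc(OCc2ccccc2C)cc1` gives 20 nM, and compound 3 `CCOC(CC(=O)O)c1ccc(OCc2cccc(C)c2)cc1` gives 35 nM. On these numbers compound 3 holds the second highest of the three; its nearest neighbour is compound 2 and its furthest is compound 1, and both gaps lie within the usual scatter, so none of the three can be ranked above another.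

Within the data shown here, the one measured step that changes a single place is a 1.8-fold higher number from compound 2 to compound 3 (0.24 log units; within the scatter), where a 3-methylphenyl replaced a 2-methylphenyl on a saturated chain carbon bound to an oxygen on an aromatic ring. Compound 4 `CCOC(CC(=O)O)c1ccc(OCc2ccc(C)cc2)cc1` is the next such change: 4-methylphenyl in place of 3-methylphenyl on a saturated chain carbon bound to an oxygen on an aromatic ring. Because a 1.8-fold higher number from compound 2 to compound 3 (0.24 log units; within the scatter) stayed within the scatter, a further move of the methyl is expected to leave the number close to where compound 3 stands, with at most a small shift to a higher value. Compound 4 is therefore expected to show a 1.4-fold higher number from compound 3 to compound 4 (0.15 log units; within the scatter) in this assay. The estimate for compound 4 is 50 nM, with a range from 20 nM to 130 nM.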

Compound 4, half-maximal effective concentration in the Free fatty acid receptor 1 assay: 370 nM
Compound 4: the middle estimate sits 7.4-fold (0.87 log units) below what was measured, and the stated range ends below it.
By their numbers in the Free fatty acid receptor 1 assay, from the lowest: compounds 2, 3 and 1 (each within the scatter of the next, the first and the last beyond it); then compound 4.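

In the Free fatty acid receptor 1 assay, the place of the methyl on the phenyl ring turns out to matter, although the atoms stay the same: 4-methylphenyl in place of 3-methylphenyl gives an 11-fold higher number from compound 3 to compound 4 (1.02 log units; beyond the scatter), and 4-methylphenyl in place of 2-methylphenyl gives a 19-fold higher number from compound 2 to compound 4 (1.27 log units; beyond the scatter). The earlier step, a 1.8-fold higher number from compound 2 to compound 3 (0.24 log units; within the scatter), could not separate the 2-methylphenyl and 3-methylphenyl compounds, so it gave no sign that the 4-methylphenyl compound would stand apart from both, which shows that a small step between two placements does not carry over to the next placement. No measurement shown here accounts for this large shift.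

Going by these compounds, whether the shift belongs to the methyl itself remains open, since a chlorine atom or a methoxy group in its place, on the same ring of compound 4, would be needed to separate the group from its placement. In a physicochemical assay for lipophilicity, at pH 7.4 (a higher number here means a more lipophilic compound, a lower number a more polar compound), compound 3 gives "not determined" (no result reported) and compound 4 gives "not determined" (no result reported), so no comparison between these two compounds can be read in that assay.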